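The source may report more compounds than this note shows. Statements on the series, on what has been measured and on what is new or still open speak of the compounds shown alone.

Measured compounds:
- Compound 1 `COc1cc(CNC(=O)CCCCCCC(C)C)ccc1OCCCCOc1ccc(C(N)=S)cc1` gives 40700 nM in a functional assay on HeLa cells (Homo sapiens) for antiproliferative activity, read by MTT assay, with a stated time of 48 h; on this read-out lower numbers stand for stronger inhibition and higher numbers for weaker inhibition.
- Compound 2 `COc1cc(CNC(=O)CCCC/C=C/C(C)C)ccc1OCCCCOc1ccc(C(N)=S)cc1` reaches only > 50000 nM, which is a limit of the assay, not a number.
- Compound 3 `COc1cc(CNC(=O)CCCC/C=C/C(C)C)ccc1OCCCCCOc1ccc(C(N)=S)cc1` gives 46400 nM.

Compound 2 stands at the limit (the limit of > 50000 nM in this assay, at which 1 of the 3 values shown sits), so its position relative to compound 1 and compound 3 is known only as a floor: the step of an at least 1.2-fold higher number from compound 1 to compound 2 (0.08 log units; that floor lies within the scatter) and the step of an at least 1.0-fold lower number from compound 2 to compound 3 (0.03 log units; that floor lies within the scatter) both sit within the scatter, and neither changes the group on the aromatic carbon.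

Compound 4 `COc1cc(CNC(=O)CCCC/C=C/C(C)C)ccc1OCCCCOc1ccc(-c2cc(=S)ss2)cc1` differs from compound 2 by a group of 6 heavy atoms (3 carbon, 3 sulfur; one five-membered aromatic ring with 2 hetero atoms) in place of a group of 3 heavy atoms (1 carbon, 1 nitrogen, 1 sulfur; no ring), on an aromatic carbon. Among the compounds with values here, no measured step touches this part of the series, so there is no direct precedent for its size or direction. Within the data shown here, the series so far spans only a narrow band of weak activity, and nothing in the measured steps suggests a large departure from it.

Compound 4 is therefore expected to give a value near 35000 nM, within 12000 nM to 60000 nM, an estimated step of an at least 1.4-fold lower number from compound 2 to compound 4 (0.15 log units; that floor lies within the scatter) that may well stay within the scatter or end again at the assay limit.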

Compound 4, half-maximal inhibitory concentration: 47100 nM
Estimate against measurement, compound 4: 1.3-fold (0.13 log units) below; the range from low to high includes it.
By their numbers in this assay, from the lowest: compounds 1, 3 and 4 (each within the scatter of the next). At a limit, above all of these: compound 2.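

Replacing the open group of 3 heavy atoms, with 1 hydrogen-bond donor, by the five-membered aromatic ring group of 6 heavy atoms, with 0 donors, on the aromatic carbon para to a large group gives an at least 1.0-fold lower number from compound 2 to compound 4 (0.02 log units; that floor lies within the scatter). Within the data shown here, this is the first measured change at this position, and even this larger group gives no sign of a gain beyond the scatter in this assay. The true size of the step stays unknown because compound 2 stands at a limit, not a number: the limit of > 50000 nM in this assay, at which 1 of the 4 values shown sits.

On these data alone, whether a carboxylic acid or an amine at this position would give a clearly different value remains open. So does whether the same five-membered ring group would behave alike with the saturated chain of compound 1 or the longer oxygen-linked chain of compound 3.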